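Toxicity of a Pyrrolidinone Series on Liver Cells

A few compounds are considered here, and "the series" means these few. Any claim that something is new, unique, unknown or untested is made for them only; others in the source may bear on it.

Compound 1 `O=C(Nc1cc(F)c(F)c(F)c1)N1CCCn2ncc(N3CC(c4ccccc4)CC3=O)c2C1`: > 2000 nM
Compound 2 `O=C1CC(Oc2ncc(F)cn2)CN1c1cnn2c1CN(C(=O)Nc1cc(F)c(F)c(F)c1)C(C1CC1)C2`: 96200 nM
Compound 3 `C[C@H]1Cn2ncc(N3CC(c4ccccc4)CC3=O)c2CN1C(=O)NCc1cc(F)c(F)c(F)c1`: > 2000 nM

Going by the values given here, in a toxicity assay on HepG2 2.2.15 cells (Homo sapiens) for cytotoxicity, read by CellTiter-Glo (on this read-out lower numbers stand for higher toxicity in this test and higher numbers for lower toxicity in this test), compound 2 is the only compound that gives a number, 96200 nM. For compound 1 the value > 2000 nM is a limit of the assay. For compound 3 the value > 2000 nM is likewise a limit (the limit of > 2000 nM in this assay, at which 2 of the 3 values shown sit). Compound 4 `O=C1CC(c2ccccn2)CN1c1cnn2c1CN(C(=O)Nc1cc(F)c(F)c(F)c1)C(C1CC1)C2` is not yet measured; it differs from compound 2 by pyridin-2-yl in place of (5-fluoropyrimidin-2-yl)oxy on a saturated ring carbon. Among the compounds with values here, no measured pair tells how such a change moves this assay, so the expected step of a 1.6-fold lower number from compound 2 to compound 4 (0.21 log units; within the scatter) is taken as none beyond the scatter, perhaps leaning to more toxicity, since compound 1 and compound 3 carrying a ring on that carbon reach only a limit. Compound 4 is therefore estimated at 60000 nM, within 15000 nM to 150000 nM.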

Compound 4, half-maximal cytotoxic concentration: 96200 nM
The estimate for compound 4 lay 1.6-fold (0.21 log units) below the measured number; the measured number falls inside the stated range.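

In this assay there is no change at the digits printed from compound 2 to compound 4 (within the scatter) when pyridin-2-yl replaces (5-fluoropyrimidin-2-yl)oxy on a saturated ring carbon. This gives a direct reading at this position: the aromatic ring carried there can go from one with 2 hetero atoms to one with 1 hetero atom without a step beyond the scatter. Compound 1 and compound 3 differ from this pair in more than one place, and neither gives a number: the limit of > 2000 nM in this assay, at which 2 of the 4 values shown sit.

The compounds shown leave open whether a group without an aromatic ring on this carbon, such as a primary amine or a carboxylic acid, would read the same.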